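Metabolic stability: pyridin-2-yl amine replacing fluorophenyl amine

A few compounds are considered here, and "the series" means these few. Any claim that something is new, unique, unknown or untested is made for them only; others in the source may bear on it.

Compound 1 `Cc1cc(C)n(-c2nc(C(F)(F)F)cc(=O)[nH]2)n1` gives 92% in an ADME assay on microsomes from liver (Rattus norvegicus) for metabolic stability, with a stated time of 30 min; a lower number here means that less of the compound is left, a higher number that more of the compound is left. Compound 3 `Cc1cc(Nc2ccc(F)cc2)n(-c2nc(C(F)(F)F)cc(=O)[nH]2)n1` gives 98%, a step of a number 6 percentage points higher from compound 1 to compound 3 (within the scatter). Compound 2 `Cc1cc(NC2CCOCC2)n(-c2nc(C(F)(F)F)cc(=O)[nH]2)n1` reaches the assay limit of > 99%, which is a limit and not a number. Within the data shown here, compound 3 therefore sits within the scatter of the one other plain number, compound 1, with the remaining value a limit. Compound 4 `Cc1cc(Nc2ccccn2)n(-c2nc(C(F)(F)F)cc(=O)[nH]2)n1` differs by pyridin-2-yl in place of 4-fluorophenyl on a nitrogen on an aromatic ring. The step that bears on this position, a number at least 1 percentage points lower from compound 2 to compound 3 (that floor lies within the scatter), stayed within the scatter, as did a number 6 percentage points higher from compound 1 to compound 3 (within the scatter). Among the measured compounds shown here, no step in this assay has moved beyond the scatter, so a step of a number 3 percentage points lower from compound 3 to compound 4 (within the scatter) is expected, none beyond the scatter. For compound 4 the estimate is 95%, between 85% and 99%.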

Compound 4, percent of the compound remaining: 96%
Compound 4: the middle estimate sits 1 percentage points below what was measured; the measured number falls inside the stated range.
By their numbers in this assay, from the lowest: compounds 1, 4 and 3 (each within the scatter of the next). At a limit, above all of these: compound 2.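

In this assay, pyridin-2-yl, with its ring hetero atom and hydrogen-bond acceptor, proves as tolerated on this nitrogen as 4-fluorophenyl (a number 2 percentage points lower from compound 3 to compound 4 (within the scatter)). The new group also stays within the scatter of the methyl compound (a number 4 percentage points higher from compound 1 to compound 4 (within the scatter)) and shows only a floor against oxan-4-yl (a number at least 3 percentage points lower from compound 2 to compound 4 (that floor lies within the scatter)). Compound 2 stands at a limit, not a number: the limit of > 99% in this assay, at which 1 of the 4 values shown sits.

All the values shown lie close together, so this read-out does not yet separate the groups on this nitrogen. Going by these compounds, whether a carboxylic acid, a piperidin-4-yl or a longer alkyl chain there would move it beyond the scatter remains open.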